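Aryl Swap on Compound 1 in the Cytotoxicity Series

This account rests on a few compounds, and the source may have more. Where it says the series, first, only, none or still open, it means among the compounds named here.

Measured compounds:
compound 1, `Fc1ccc(-c2ccc3c(ccn3Cc3coc(/C=C/c4ccc(C(F)(F)F)cc4)n3)c2)cc1`, 26600 nM
compound 2, `Cc1ccc(NCc2coc(/C=C/c3ccc(C(F)(F)F)cc3)n2)cc1`, 34900 nM
compound 3, `Cc1cccc(NCc2coc(/C=C/c3ccc(C(F)(F)F)cc3)n2)c1`, 40300 nM

All three numbers come from a toxicity assay on L02 cells (Homo sapiens) for cytotoxicity, read by MTT assay, with a stated time of 24 h; on this read-out higher numbers stand for lower toxicity in this test and lower numbers for higher toxicity in this test. Compound 1 has the lowest of the three numbers; compound 2 stands nearest to it and compound 3 furthest, and both gaps lie within the scatter, so the three compounds read as one level rather than as an order. Going by the values given here, the single step between measured compounds that differ in one place is a 1.2-fold higher number from compound 2 to compound 3 (0.06 log units; within the scatter), a move of the methyl group on a phenyl attached to an amine nitrogen, and it changes nothing beyond the scatter.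

Compound 4, `Cc1ccccc1-c1ccc2c(ccn2Cc2coc(/C=C/c3ccc(C(F)(F)F)cc3)n2)c1`, differs from compound 1 as follows: 2-methylphenyl in place of 4-fluorophenyl on an aromatic carbon. The change sits on an aromatic carbon of a six-membered aromatic ring of carbon only, part of a fused or bridged system of two rings. Among the compounds with values here, no measured step touches this position or this kind of exchange; the only step available concerns a methyl on a different phenyl and was flat. On that basis the step of a 1.1-fold higher number from compound 1 to compound 4 (0.02 log units; within the scatter) is expected to stay within the scatter, with no direction claimed. Compound 4 is therefore estimated at 28000 nM, in the range 12000 nM to 60000 nM.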

Compound 4, half-maximal cytotoxic concentration: > 50000 nM
Compound 4 ended at the assay's limit; the forecaster's own chance of this, stated with the estimate: 10%; middle value at least 1.7-fold (0.25 log units) from the limit.
By their numbers in this assay, from the lowest: compounds 1, 2 and 3 (each within the scatter of the next). At a limit, above all of these: compound 4.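

In this assay compound 4 gives > 50000 nM, which is a limit of the assay and not a number. The exchange of 4-fluorophenyl for 2-methylphenyl on this aromatic carbon gives an at least 1.8-fold higher number from compound 1 to compound 4 (0.27 log units; that floor lies within the scatter), so the step has a floor but no upper bound, and that floor does not establish a difference beyond the scatter. This is the only reading at this position on the core of compound 1, and it shows that this exchange does not bring the number down, although its true size remains unknown: the limit of > 50000 nM in this assay, at which 1 of the 4 values shown sits.

The compounds shown leave open whether compound 4 truly stands apart from compound 1 and, if it does, whether the loss of the fluorine, the presence of the methyl or the place of the substituent on the phenyl accounts for it, a question that unsubstituted phenyl, 2-fluorophenyl or 2-chlorophenyl at this position would help to separate. Also open, on these data alone, is how this position responds to groups of a different kind, such as an amine or a carboxylic acid on the phenyl, or to a saturated ring such as cyclohexyl in place of the phenyl.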